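The source may report more compounds than this note shows. Statements on the series, on what has been measured and on what is new or still open speak of the compounds shown alone.

Measured in a functional assay on PC-3 cells (Homo sapiens) for inhibition, read by colorimetric assay and MTT assay, with a stated time of 72 h; on this read-out lower numbers stand for stronger inhibition and higher numbers for weaker inhibition:

compound 1, `COc1ccc2c(c1)-c1cnc(n1C)OCCCCCCCCO2`, gives 40000 nM
compound 2, `Cn1c2cnc1OCCCCCCCCOc1ccc(F)cc1-2`, gives 52000 nM
compound 3, `C=CCCCCOc1ccc(OC)cc1-c1cnc(OCCC=C)n1C`, gives 43000 nM

Compound 1 and compound 2 share one core and differ in a single place, (fluoro in place of methoxy on an aromatic carbon). The measured step is a 1.3-fold higher number from compound 1 to compound 2 (0.11 log units; within the scatter), so the two numbers cannot be told apart. Compound 3 carries an open-chain core; how it differs from the core of compound 1 is not broken down here, and its value sits close to those of compound 1 and compound 2.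

Compound 4, `C=CCCCCOc1ccc(F)cc1-c1cnc(OCCC=C)n1C`, is not yet measured. It arises from compound 3 by fluoro in place of methoxy on an aromatic carbon. This is the same kind of change as that from compound 1 to compound 2, but the surroundings differ: in compound 2 the ring is part of a fused or bridged system of three rings, meta to a fused ring and para to a fused ring, whereas in compound 4 the ring is meta to a large group and para to a (hex-5-en-1-yl)oxy group.

Since the earlier step of a 1.3-fold higher number from compound 1 to compound 2 (0.11 log units; within the scatter) was small, a similar step is expected for compound 4, namely a 1.3-fold higher number from compound 3 to compound 4 (0.11 log units; within the scatter) in this assay. Compound 4 is thus estimated at 55000 nM, likely between 25000 nM and 120000 nM.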

Compound 4, half-maximal inhibitory concentration: 52000 nM
Compound 4: middle estimate off by 1.1-fold (0.02 log units), on the high side, within the range that was stated.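

Fluoro in place of methoxy gives a 1.2-fold higher number from compound 3 to compound 4 (0.08 log units; within the scatter) in this assay, so on the open-chain core this swap makes no change that can be told from the scatter. The same swap on the core of compound 1 gives a matching result, and the two steps cannot be told apart: the same change on two cores in this assay, a 1.3-fold higher number (0.11 log units; within the scatter) from compound 1 to compound 2 and a 1.2-fold higher number (0.08 log units; within the scatter) from compound 3 to compound 4, 1.1-fold (0.03 log units) apart, within the scatter of two such steps. This shows that, for these two pairs, the swap has the same outcome on both cores, but both steps are too small to read, so it does not show that a larger effect would carry over from one core to the other, and it says nothing about any third core.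

The compounds shown leave open whether a different group in the same place on the ring, such as an amine or a carboxylic acid, would move the number on either core. They also leave open whether a shorter or longer chain in place of the (hex-5-en-1-yl)oxy group would change the result.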